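The compounds below may be only part of what the source reports. "The series", "measured", "known", "first", "only" and "open" are said of these compounds alone.

The compounds measured so far in a functional assay on 143B cells (Homo sapiens) for antiproliferative activity, read by MTT assay, with a stated time of 48 h; on this read-out higher numbers stand for weaker inhibition and lower numbers for stronger inhibition:

compound 1 `O=C(Nc1cccc(/C=C/C(=O)c2nc3ccccc3[nH]2)c1)c1ccccc1` gives 8340 nM
compound 2 `Cc1cccc(C(=O)Nc2cccc(/C=C/C(=O)c3nc4ccccc4[nH]3)c2)c1` gives 4880 nM
compound 3 `O=C(/C=C/c1cccc(NS(=O)(=O)c2ccccc2Cl)c1)c1nc2ccccc2[nH]1` gives 4790 nM

Compound 1 stands highest of these three numbers, but only narrowly: the step of a 1.7-fold lower number from compound 1 to compound 2 (0.23 log units; within the scatter) and the step of a 1.7-fold lower number from compound 1 to compound 3 (0.24 log units; within the scatter) both stay within the scatter, as does a 1.0-fold lower number from compound 2 to compound 3 (0.01 log units; within the scatter). Compound 4 `O=C(/C=C/c1cccc(NS(=O)(=O)c2cccc(Cl)c2)c1)c1nc2ccccc2[nH]1` differs from compound 1 by (3-chlorophenyl)sulfonyl in place of benzoyl on a nitrogen on an aromatic ring. The step from compound 1 to compound 3 bears on this most closely, since it also replaces the benzoyl with a chlorophenylsulfonyl group, and it stayed within the scatter. No step beyond the scatter is therefore expected in this assay. Compound 4 is estimated at 5500 nM, between 2500 nM and 12000 nM, an expected step of a 1.5-fold lower number from compound 1 to compound 4 (0.18 log units; within the scatter).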

Compound 4, half-maximal inhibitory concentration: 2510 nM
Beside the measured number, compound 4's estimate is 2.2-fold (0.34 log units) above it, within the range that was stated.
By their numbers in this assay, from the lowest: compounds 4, 3, 2 and 1 (each within the scatter of the next, the first and the last beyond it).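

In this assay, for the compounds shown here, the change from benzoyl to (3-chlorophenyl)sulfonyl on the nitrogen gives the first step beyond the scatter (a 3.3-fold lower number from compound 1 to compound 4 (0.52 log units; beyond the scatter)), though compound 4 stays within the scatter of its nearest relatives (a 1.9-fold lower number from compound 3 to compound 4 (0.28 log units; within the scatter) and a 1.9-fold lower number from compound 2 to compound 4 (0.29 log units; within the scatter)). Moving the chlorine therefore cannot be read as a real change on its own. Nothing available explains the step.

Going by these compounds, whether the step belongs to the sulfonyl or to the chlorine stays open, and a plain phenylsulfonyl group on that nitrogen would separate the two. On these data alone, how an amine or a carboxylic acid on that ring would read is equally open.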